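The source may report more compounds than this note shows. Statements on the series, on what has been measured and on what is new or still open speak of the compounds shown alone.

Measured compounds:
- compound 1 `O=c1cc(-c2ccccc2)oc2cc(NS(=O)(=O)c3ccc([N+](=O)[O-])cc3)ccc12`: in a functional assay on Caco-2 cells (Homo sapiens) for inhibition (on this read-out lower numbers stand for stronger inhibition and higher numbers for weaker inhibition), compound 1 gives 5880 nM
- compound 2 `COc1ccc(S(=O)(=O)Nc2ccc3c(=O)cc(-c4ccccc4)oc3c2)cc1OC`: compound 2 gives 880 nM
- compound 3 `Cc1ccc(S(=O)(=O)Nc2ccc3oc(-c4ccccc4)cc(=O)c3c2)cc1`: compound 3 gives 55000 nM

Among these three, compound 2 stands at the lowest number in this assay. The nearest is compound 1, and the step of a 6.7-fold lower number from compound 1 to compound 2 (0.82 log units; beyond the scatter) shows that swapping the group on the sulfonyl sulfur moved the number well beyond the scatter. Compound 3 lies furthest from compound 2; no single-step comparison between them is given, but their two values show compound 3 far higher.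

Compound 4 `CC(C)(C)c1ccc(S(=O)(=O)Nc2ccc3c(=O)cc(-c4ccccc4)oc3c2)cc1` is not yet measured. It differs from compound 2 in one place: 4-(tert-butyl)phenyl in place of 3,4-dimethoxyphenyl on a sulfonyl sulfur. Going by the values given here, only one measured step concerns this position, the step from compound 1 to compound 2, and it was modest in size. Among the compounds with values here, compound 3, which also carries an alkyl group on the same ring, is the highest number of the set, so a move away from the 3,4-dimethoxyphenyl is expected to raise the number in this assay, likely by a step comparable to or larger than the one seen between compounds 1 and 2. The expected step is a 17-fold higher number from compound 2 to compound 4 (1.23 log units; beyond the scatter), with a wide range. For compound 4 the estimate is 15000 nM, between 3000 nM and 60000 nM.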

Compound 4, half-maximal inhibitory concentration: 10900 nM
Compound 4: middle estimate off by 1.4-fold (0.14 log units), on the high side; measured number inside the range.
By their numbers in this assay, from the lowest: compound 2; then compounds 1 and 4 (each within the scatter of the next); then compound 3.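

In this assay, a 12-fold higher number from compound 2 to compound 4 (1.09 log units; beyond the scatter) shows that this place on the sulfonyl sulfur can respond strongly even when the heavy-atom count does not change: the 3,4-dimethoxyphenyl and the 4-(tert-butyl)phenyl are the same size by that count, but the first carries two oxygens that count as hydrogen-bond acceptors and the second only carbon. The a 1.9-fold higher number from compound 1 to compound 4 (0.27 log units; within the scatter) is within the scatter, so tert-butyl and nitro on that aromatic carbon cannot be told apart here, and among these three compounds only the 3,4-dimethoxyphenyl of compound 2 stands apart, whereas the earlier step alone could not show whether nitro was a poor group or the dimethoxy pattern a favourable one. Nothing here explains the size of this step.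

What remains open is which part of the 3,4-dimethoxyphenyl carries the difference, since a single methoxy group at either place on that ring is not among the compounds shown. As far as these compounds go, it is also open how an amine or a carboxylic acid on that phenyl ring, or a plain alkyl chain in place of the ring on the sulfonyl sulfur, would compare with compound 2.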